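The source may hold more compounds than are shown below. What is called first, only, known or untested is meant among the compounds shown, and "the series" means these compounds.

Measured so far:
- compound 1, `O=[N+]([O-])c1cccc(Cn2cc(COc3ccccc3)nn2)c1`, 25.3 ug/mL
- compound 2, `Clc1cc(Cl)c(OCc2cn(Cc3ccc(Br)cc3)nn2)c(Cl)c1`, 14 ug/mL
- compound 3, `O=[N+]([O-])c1ccc(Cn2cc(COc3ccc([N+](=O)[O-])cc3I)nn2)cc1`, 16.8 ug/mL

All three were read in a physicochemical assay, read by spectrophotometry, with a stated time of 30 min; a higher number here means a weaker inhibitor, a lower number a stronger inhibitor. Among these three numbers compound 3 stands second highest: compound 2 is its nearest neighbour and compound 1 its furthest, and both gaps are within the usual scatter of this assay, so no order among the three can be claimed.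

Compound 4, `O=[N+]([O-])c1ccc(OCc2cn(Cc3ccc(Br)cc3)nn2)c(I)c1`, has not yet been measured. It differs from compound 3 in one place: bromo in place of nitro on an aromatic carbon. For the measured compounds named here, no step between two measured compounds isolates this change, so its size is not known from the data. Compound 2, which also carries a bromophenyl group, and compound 3 give numbers within the scatter of each other, which offers no hint of a shift in either direction. Compound 4 is therefore expected to land close to compound 3, with an estimated step of a 1.1-fold lower number from compound 3 to compound 4 (0.05 log units; within the scatter) that is not beyond the scatter. Compound 4 is estimated at 15 ug/mL, within a range of 7.5 ug/mL to 30 ug/mL.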

Compound 4, half-maximal inhibitory concentration: 18.5 ug/mL
For compound 4 the middle estimate is 1.2-fold (0.09 log units) below the measured one; the measured number falls inside the stated range.
By their numbers in this assay, from the lowest: compounds 2, 3, 4 and 1 (each within the scatter of the next).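

Replacing the 4-nitrophenyl of the core with 4-bromophenyl in this assay gives a 1.1-fold higher number from compound 3 to compound 4 (0.04 log units; within the scatter) and is the only step shown that isolates this change. At this place, para to a large group, bromo takes the place of nitro with no shift that can be told from the scatter, although bromo has fewer heavy atoms and no hydrogen-bond acceptors. Nothing shown gives a measured reason for this result.

The compounds shown leave open whether an amine or a carboxylic acid at this place would give a number beyond the scatter. They also leave open whether the same change would behave alike in another compound.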